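Series notes: fluoro for chloro on the benzyl group

This account rests on a few compounds, and the source may have more. Where it says the series, first, only, none or still open, it means among the compounds named here.

Measured so far:
- Compound 1 `Cc1ccccc1Nc1nc(SCc2cn(Cc3ccc(Cl)cc3)nn2)nc(-c2ccccc2)c1C#N`. In a functional assay on MCF7 cells (Homo sapiens) for inhibition, read by MTT assay, with a stated time of 72 h (a higher number here means a weaker inhibitor, a lower number a stronger inhibitor), compound 1 gives > 64000 nM, which is a limit of the assay and not a number.
- Compound 2 `Cc1ccc(Nc2nc(SCc3cn(Cc4ccc(Cl)cc4)nn3)nc(-c3ccccc3)c2C#N)cc1`. In this assay compound 2 gives > 64000 nM, again a limit of the assay rather than a number.

Among the compounds with values here, the single step between measured compounds, a step that the two limits leave unreadable from compound 1 to compound 2, cannot be read, since both of its ends sit at the limit of > 64000 nM in this assay, at which 2 of the 2 values shown sit. Compound 2 therefore stands at the limit, with no number to place it against anything else in the series.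

Compound 3 `Cc1ccc(Nc2nc(SCc3cn(Cc4ccc(F)cc4)nn3)nc(-c3ccccc3)c2C#N)cc1` differs from compound 2 by fluoro in place of chloro on an aromatic carbon. Within the data shown here, no measured step bears on this change; the only step available, a step that the two limits leave unreadable from compound 1 to compound 2, concerns another part of the molecule and is itself unreadable. The values shown give no indication of a shift beyond the scatter, and the likeliest outcome is a further limit. Compound 3 is therefore estimated to sit near 80000 nM in this assay, with an expected range from 30000 nM to 250000 nM. The implied step, a step that the limit leaves unreadable from compound 2 to compound 3, is expected to lie within the scatter.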

Compound 3, half-maximal inhibitory concentration: 51100 nM
The estimate for compound 3 lay 1.6-fold (0.19 log units) above the measured number; the measured number falls inside the stated range.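

In this assay compound 3 gives 51100 nM, the only actual number among the compounds shown, so the 4-fluorobenzyl compound offers the series its one measured reference point. From the compounds shown here alone, exchanging the 4-chlorobenzyl group for the 4-fluorobenzyl group gives an at least 1.2-fold lower number from compound 2 to compound 3 (0.09 log units; that floor lies within the scatter), so the data show a lower number but do not establish a shift beyond the scatter, and the true size of the step remains unknown. Compound 2 remains at a limit of the assay, not a number: the limit of > 64000 nM in this assay, at which 2 of the 3 values shown sit.

The step between the 2-methylphenyl and 4-methylphenyl compounds cannot be read, and the effect of moving the methyl group is therefore unknown, including in the presence of the 4-fluorobenzyl group. The compounds shown also leave open how a methoxy group, an amine or a carboxylic acid in place of the halogen on the benzyl group would read in this assay, and whether any such replacement would give a step clearly beyond the scatter.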